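This account rests on a few compounds, and the source may have more. Where it says the series, first, only, none or still open, it means among the compounds named here.

Measured compounds:
compound 1 `Nc1nc(O)c2c(n1)n(C1OC(CO)[C@@H](O)[C@H]1O)c(=O)n2C/C=C/c1ccccc1` — 73%
compound 2 `N#Cc1ccc(Cn2c(=O)n(C3OC(CO)[C@@H](O)[C@H]3O)c3nc(N)nc(O)c32)cc1` — 50%

Among the measured compounds shown here, in a functional assay on the whole organism (B cells) with Mus musculus as the target (on this read-out lower numbers stand for smaller maximal responses and higher numbers for larger maximal responses), compound 2 stands as the lower of the two numbers known so far, with compound 1 higher by a number 23 percentage points lower from compound 1 to compound 2 (beyond the scatter). Compound 3 `CCCCn1c(=O)n(C2OC(CO)[C@@H](O)[C@H]2O)c2nc(N)nc(O)c21` differs from compound 2 by propyl in place of 4-cyanophenyl on a saturated chain carbon bound to an aromatic nitrogen. For the measured compounds named here, the single step that bears on this place is a number 23 percentage points lower from compound 1 to compound 2 (beyond the scatter), a modest drop, but neither end of it carries a plain chain, so its direction cannot be carried over. The change from compound 2 to compound 3 is expected to give a number 8 percentage points higher from compound 2 to compound 3 (within the scatter), a shift not clearly beyond the scatter. For compound 3 the estimate in this assay is 58%, within 35% to 82%.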

Compound 3, largest response reached (reported as maximal response), in percent of the reference or control that the assay uses: 86%
The estimate for compound 3 lay 28 percentage points below the measured number, and the stated range ends below it.
By their numbers in this assay, from the lowest: compound 2; then compound 1; then compound 3.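

On a saturated chain carbon bound to an aromatic nitrogen, propyl gives the highest number of the three in this assay with a number 36 percentage points higher from compound 2 to compound 3 (beyond the scatter) and a number 13 percentage points higher from compound 1 to compound 3 (beyond the scatter) as the two steps up. A group without a ring thus tops this small set, so neither 4-cyanophenyl nor 2-phenylethenyl is needed for a large maximal response. Nothing on hand accounts for this order. Still open, going by these compounds, is whether a longer chain keeps the number of compound 3 and whether an amine at the chain end lowers it.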